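The compounds below may be only part of what the source reports. "The series", "measured", "known", "first", "only" and "open" are said of these compounds alone.

Three close relatives share one core, a bicyclic urea carrying an alkyl group on one nitrogen and an ether chain that links through two carbons to a second aromatic ring. Compound 1 `CC(C)n1c(=O)[nH]c2ccc(OCCOc3ccc(Cl)cc3)cc21` carries an isopropyl group on the core nitrogen, and in an assay on cells for inhibition of Amine oxidase [flavin-containing] A (Homo sapiens), read by fluorescence, with stated times of 30 min and 15 min (a higher number here means a weaker inhibitor, a lower number a stronger inhibitor), compound 1 gives "not determined" (no result reported). Compound 2 `CCn1c(=O)[nH]c2ccc(OCCOc3ccc(Cl)cc3)cc21` carries an ethyl group there, and in this assay compound 2 likewise gives "not determined" (no result reported), so compound 2 stands without a number of its own. Compound 3 `CCn1c(=O)[nH]c2ccc(OCCOc3cccc(F)c3)cc21` keeps the ethyl group and carries a fluorine on the second ring; in this assay compound 3 reaches only the limit of the assay, > 500000 nM, which is not a number. For the measured compounds named here, that single limit of > 500000 nM in this assay, at which 1 of the 3 values shown sits, is the only measured evidence here.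

Compound 4 `CCn1c(=O)[nH]c2ccc(OCCOc3ccc(C(C)C)cc3)cc21` is compound 2 with one change: isopropyl in place of chloro on an aromatic carbon. Going by the values given here, compound 2 has no number, so no step between them can be sized. Among the compounds with values here, no step in this assay is expected to be placed beyond the scatter on present evidence. The one measured relative, compound 3, sits at a limit, so weak inhibition is the expectation. For compound 4 in this assay the estimated value is 300000 nM, expected to fall between 50000 nM and 1000000 nM.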

Compound 4, half-maximal inhibitory concentration: > 500000 nM
Compound 4: only a limit was reported (the forecaster's own chance of this, stated with the estimate: 70%); middle value at least 1.6-fold (0.22 log units) from the limit.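

In this assay compound 4 gives > 500000 nM, which is a limit and not a number. For the compounds shown here, compound 2 has no number to set against it, so no step between compound 2 and compound 4 can be read. The compounds shown leave open whether changing the group on the second ring alters inhibition at all.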